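Sulfonamide chain swap in a pyrimidinone growth-inhibitor series

The source may report more compounds than this note shows. Statements on the series, on what has been measured and on what is new or still open speak of the compounds shown alone.

Measured compounds:
Compound 1, `CC[C@@H]1C(=O)N(C)c2cnc(Nc3ccc(S(=O)(=O)NCCO)cc3)nc2N1C1CCCC1`, 546 nM
Compound 2, `CCC1C(=O)N(C)c2cnc(-n3ccc4cc(C(=O)NCC(C)C)ccc43)nc2N1c1ccn(C)n1`, 5600 nM
Compound 3, `CCC1C(=O)N(C)c2cnc(-n3ccc4cc(C(=O)NC(C)C)ccc43)nc2N1c1ccn(C)n1`, 8910 nM

In a functional assay on K562 cells (Homo sapiens) for antiproliferative activity, read by CCK-8 assay, with a stated time of 72 h (a lower number here means a stronger inhibitor of growth, a higher number a weaker inhibitor of growth), compound 1 gives 546 nM, the lowest of the three numbers, and its gap to both compound 2 and compound 3 lies beyond the scatter, so compound 1 is the most potent of the measured set. Compound 2 and compound 3 share a different core and differ only in the amide substituent; the step of a 1.6-fold higher number from compound 2 to compound 3 (0.20 log units; within the scatter) shows that exchanging one small branched alkyl for another at an amide-type nitrogen left the number essentially unchanged.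

Compound 4, `CC[C@@H]1C(=O)N(C)c2cnc(Nc3ccc(S(=O)(=O)NCC(C)C)cc3)nc2N1C1CCCC1`, is the one not yet measured. It differs from compound 1 by isopropyl in place of hydroxymethyl on a saturated chain carbon bound to a sulfonamide nitrogen. Among the measured compounds shown here, the only measured step that bears on it is the alkyl swap from compound 2 to compound 3, and that step was within the scatter; it concerns a different nitrogen on a different core, so it carries limited weight. For the measured compounds named here, no measured pair tests the loss of a hydroxyl on this sulfonamide chain. The step of a 1.2-fold higher number from compound 1 to compound 4 (0.08 log units; within the scatter) is therefore expected to be small, with no confident direction. Compound 4 is estimated at 650 nM, within 250 nM to 1700 nM.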

Compound 4, concentration for 50% growth inhibition: 705 nM
For compound 4 the middle estimate is 1.1-fold (0.04 log units) below the measured one; measured number inside the range.
By their numbers in this assay, from the lowest: compounds 1 and 4 (each within the scatter of the next); then compounds 2 and 3 (each within the scatter of the next).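

Among the compounds shown here, the swap of hydroxymethyl for isopropyl on a saturated chain carbon bound to a sulfonamide nitrogen gives the first direct reading of this chain in this assay (a 1.3-fold higher number from compound 1 to compound 4 (0.11 log units; within the scatter)), whereas the earlier compounds offered only an alkyl exchange on an amide-type nitrogen of another core. The hydroxyl is therefore not required to keep the number in this range, and a group with 0 hydrogen-bond donors and 0 hydrogen-bond acceptors, carrying 3 carbon atoms, serves as well here as hydroxymethyl with its 1 hydrogen-bond donor and 1 hydrogen-bond acceptor. No supporting measurement is available to explain why the two numbers stand so close.

Still open is whether this place accepts any chain end at all, since only 2-hydroxyethyl and isobutyl are shown on the sulfonamide nitrogen, and an amine, a carboxylic acid or a longer chain could give a different number. It also remains open whether the same closeness of the two chains would hold on the core of compound 2 or in a cell line other than the one shown.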